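A few compounds are considered here, and "the series" means these few. Any claim that something is new, unique, unknown or untested is made for them only; others in the source may bear on it.

Measured in a functional assay on T-24 cells (Homo sapiens) for cytotoxicity, read by colorimetric assay and MTT assay (on this read-out lower numbers stand for stronger inhibition and higher numbers for weaker inhibition), were these compounds:
Compound 1 `COc1cccc2cc(-c3ccccc3)c(O)nc12` gives 10000 nM
Compound 2 `COc1cc(OC)c2cc(-c3ccccc3)c(O)nc2c1` gives 10000 nM
Compound 3 `COc1ccc(-c2cc3c(OC)cc(OC)cc3n(CC#N)c2=O)cc1` gives 10000 nM

On these numbers compound 3 stands level with compound 1 and compound 2, and nothing separates the three at the digits reported. The next compound, compound 4 `COc1ccc(-c2cc3c(OC)cc(OC)cc3n(CCC#N)c2=O)cc1`, shares the core of compound 3 and differs in one place. It carries cyanomethyl in place of cyano on a saturated chain carbon bound to an aromatic nitrogen, which read one bond further out is cyanomethyl to 2-cyanoethyl: cyanomethyl in place of cyano on a saturated chain carbon bound to an aromatic nitrogen. For the measured compounds named here, no pair of measured compounds differs in one place only, so the data offer no step to scale this change against. With compound 3 at 10000 nM and level with the other two, no direction is indicated, and in this assay no step beyond the scatter is expected. The expected no change at the digits printed from compound 3 to compound 4 (within the scatter) is accordingly estimated as no real change. Compound 4 is expected at 10000 nM as the middle estimate, with an estimated range from 5000 nM to 20000 nM around it.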

Compound 4, half-maximal inhibitory concentration: 10000 nM
Compound 4: the middle estimate sits on the measured number at the digits printed, and the stated range covers the measured number.
By their numbers in this assay, from the lowest: compounds 1, 2, 3 and 4 (each within the scatter of the next).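

In this assay, for the compounds shown here, the step of no change at the digits printed from compound 3 to compound 4 (within the scatter) is the first that can be read at this place, and it belongs to cyanomethyl in place of cyano on a saturated chain carbon bound to an aromatic nitrogen. Going from the cyanomethyl to the 2-cyanoethyl group on the aromatic nitrogen, with the nitrile kept, therefore does not separate these two compounds on this read-out. Nothing available bears on why they read alike.

Going by these compounds, whether an amine, a carboxylic acid or a longer chain ending in a nitrile at this place would read differently remains open. With a single step at this place, and that step within the scatter, the compounds shown do not tell whether any group there can move the value in this assay at all.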